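Amide nitrogen substituent change in a phosphatase inhibitor series

The compounds below may be only part of what the source reports. "The series", "measured", "known", "first", "only" and "open" are said of these compounds alone.

Measured so far:
Compound 1 `CCCNC(=O)COc1ccc2cc(C(O)(C(F)(F)F)C(F)(F)F)c(O)cc2c1` gives > 20000 nM in an assay on isolated protein for inhibition of receptor-type tyrosine-protein phosphatase C (Homo sapiens), read by spectrophotometry; a lower number here means a stronger inhibitor, a higher number a weaker inhibitor.
Compound 2 `Oc1ccc(-c2ccccc2)cc1C(O)(C(F)(F)F)C(F)(F)F` gives > 500000 nM in this assay.

Compound 1 stands only at a limit of this assay, not at a number (the limit of > 20000 nM in this assay, at which 1 of the 2 values shown sits). Compound 2 likewise sits at a limit of this assay (the limit of > 500000 nM in this assay, at which 1 of the 2 values shown sits). Within the data shown here, the two compounds share no single-point difference, so no measured step is available, and nothing in the data says how either value would move with a change at the amide.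

Compound 3 `CC(C)c1ccc(NC(=O)COc2ccc3cc(C(O)(C(F)(F)F)C(F)(F)F)c(O)cc3c2)cc1` differs from compound 1 by 4-isopropylphenyl in place of propyl on an amide-type nitrogen. With only limits on hand, the direction of the step in this assay is open; a small gain, not clearly beyond the scatter, is expected. For compound 3 a value of about 15000 nM is estimated, expected to fall between 4000 nM and 60000 nM. The step of an at least 1.3-fold lower number from compound 1 to compound 3 (0.12 log units; that floor lies within the scatter) is thus expected, with a real chance that only a limit is again reported.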

Compound 3, half-maximal inhibitory concentration: 7800 nM
Estimate against measurement, compound 3: 1.9-fold (0.28 log units) above; the measured number falls inside the stated range.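

Among these compounds, the change of propyl to 4-isopropylphenyl on the amide-type nitrogen gives an at least 2.5-fold lower number from compound 1 to compound 3 (0.40 log units; beyond the scatter) in this assay and makes compound 3 (7800 nM) the first compound here to be read as a number rather than a limit. The substituent on this nitrogen alone can therefore move the read-out beyond the scatter on the shared core. From the compounds shown here alone, the true size of the step remains unknown, and it stands only as a floor because compound 1 sits at a limit of the assay: the limit of > 20000 nM in this assay, at which 1 of the 3 values shown sits.

Going by these compounds, whether the change in the read-out belongs to the aromatic ring or to the isopropyl group on it stays open, and an unsubstituted phenyl on the same nitrogen would separate the two. On these data alone, how far the trend carries is also open, for instance with a 4-carboxyphenyl group or a longer alkyl chain such as octyl at this position.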